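Moving the chlorine on the sulfonamide aryl ring

The source may hold more compounds than are shown below. What is called first, only, known or untested is meant among the compounds shown, and "the series" means these compounds.

Measured compounds:
- compound 1, `O=C(Nc1cccc(S(=O)(=O)Nc2ccccc2)c1)c1ccc(Cl)cc1Cl`: "not determined" (no result reported)
- compound 2, `Cc1cc(Cl)ccc1C(=O)Nc1ccc(S(=O)(=O)Nc2ccccc2)cc1`: 123%
- compound 3, `O=C(Nc1ccc(S(=O)(=O)Nc2ccc(Cl)cc2)cc1)c1ccc(Cl)cc1Cl`: "not determined" (no result reported)

Among the compounds with values here, only one of the three compounds carries a number. In a functional assay on HEK293 cells for agonist activity at probable G-protein coupled receptor 27 (Homo sapiens), read by a luciferase reporter and beta-arrestin recruitment, with a stated time of 10 min (on this read-out lower numbers stand for smaller maximal responses and higher numbers for larger maximal responses), compound 2 gives 123%, a maximal response larger than the control. In this assay compound 1 gives "not determined" (no result reported). In this assay, within the data shown here, compound 3 gives "not determined" (no result reported), so compound 3 stands without a value, and no step between measured compounds can be drawn from it.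

Compound 4, `O=C(Nc1ccc(S(=O)(=O)Nc2ccccc2Cl)cc1)c1ccc(Cl)cc1Cl`, shares all its atoms with compound 3 and differs only in how they are joined: 2-chlorophenyl in place of 4-chlorophenyl on a sulfonamide nitrogen. With nothing known for compound 3, no direction can be read from a neighbour, and the only anchor is the response of compound 2, which has a different amide part and an unsubstituted phenyl on the sulfonamide nitrogen.

Any step in this assay from compound 3 to compound 4 is therefore unknown in size and direction. Compound 4 is estimated to give a maximal response of about 100%, with a range from 40% to 140%, this being an expectation resting on compound 2 alone.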

Compound 4, largest response reached (Emax), in percent of the reference or control that the assay uses: 53%
Compound 4: middle estimate off by 47 percentage points, on the high side; the measured number falls inside the stated range.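

In this assay, within the data shown here, compound 3 gives "not determined" (no result reported) and compound 4 gives 53% so no step between these two compounds can be read. Nothing shown here offers an explanation for the response of compound 4. Still open, from the compounds shown here alone, is whether 2-chlorophenyl in place of 4-chlorophenyl raises the maximal response, lowers it or leaves it unchanged.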